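The source may report more compounds than this note shows. Statements on the series, on what has been measured and on what is new or still open speak of the compounds shown alone.

Within the data shown here, compound 1 `O=C(COc1ccc(C(=O)/C=C/c2ccccc2Cl)cc1)N[C@H]1CCOC1=O` is the only member of this small set that returns a number: in a functional assay on DU-145 cells (Homo sapiens) for antiproliferative activity, read by MTT assay, with a stated time of 72 h (a lower number here means a stronger inhibitor, a higher number a weaker inhibitor), compound 1 gives 3240 nM. Compound 2 `C=CCc1ccc(OCCSC(=S)N[C@H]2CCOC2=O)c(OC)c1` reaches only a limit of this assay, reported as > 64000 nM. Compound 3 `O=C(CNc1ccc(Br)cc1)N[C@H]1CCOC1=O` likewise stops at a limit, reported as > 64000 nM. Compound 1 therefore stands alone on the scale, the other two sitting at the limit of > 64000 nM in this assay, at which 2 of the 3 values shown sit, rather than at a measured point. Among the measured compounds shown here, no step between two measured compounds can be drawn from these three, so there is no measured pair to set the size of any change.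

Compound 4 `O=C(COc1ccc(C(=O)/C=C/c2cccc(F)c2)cc1)N[C@H]1CCOC1=O` keeps the shared core of compound 1 and differs from it in one place: 3-fluorophenyl in place of 2-chlorophenyl on a double-bonded chain carbon bound to a double-bonded chain carbon. With nothing measured to lean on, the step from compound 1 to compound 4 is expected to be small, a change no larger than the scatter of repeated measurements, in either direction a 1.1-fold higher number from compound 1 to compound 4 (0.03 log units; within the scatter). Compound 4 is accordingly estimated at 3500 nM in this assay, with a range from 1200 nM to 10000 nM.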

Compound 4, half-maximal inhibitory concentration: 17200 nM
Compound 4: middle estimate off by 4.9-fold (0.69 log units), on the low side; measured number outside the range, above it.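

Among these compounds, this is the first measured step, and it shows that the group on the double-bonded chain carbon matters in this assay: exchanging 2-chlorophenyl for 3-fluorophenyl, with the shared core unchanged, gives a 5.3-fold higher number from compound 1 to compound 4 (0.72 log units; beyond the scatter). The two groups match in the counts computed for them, yet the step lies beyond the usual scatter, so this position responds to a change that leaves those counts untouched. Compound 4 still gives a number instead of reaching the limit, which remains the only reading for the other two compounds: the limit of > 64000 nM in this assay, at which 2 of the 4 values shown sit.

The halogen and its place change together in this one step, so the compounds shown cannot separate the two. Open too, as far as these compounds go, are fluorine in the place of the chlorine of compound 1, chlorine in the place of the fluorine of compound 4, and a plain phenyl or a methoxy group at this position.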